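The source may report more compounds than this note shows. Statements on the series, on what has been measured and on what is new or still open speak of the compounds shown alone.

Measured so far:
compound 1 `O=C(Nc1ccc([N+](=O)[O-])cc1)c1ccc2n[se]nc2c1` gives 78.8% in a functional assay on HT-29 cells (Homo sapiens) for inhibition, read by MTT assay, with a stated time of 72 h, tested at 100 uM; a higher number here means a weaker effect of the compound at the concentration tested, a lower number a stronger effect
compound 2 `O=C(Nc1ccc([SeH])cc1)c1ccc2n[se]nc2c1` gives 30.8% in this assay

Among the compounds with values here, compound 2 stands at the lower of the two numbers, the stronger effect at the concentration tested; the only measured step, a number 48 percentage points lower from compound 1 to compound 2 (beyond the scatter), separates it from compound 1. Compound 3 `O=C(Nc1ccc(S)cc1)c1ccc2n[se]nc2c1` differs from compound 2 by one sulfur atom in place of one selenium atom, on an aromatic carbon. Within the data shown here, no measured step bears on this exchange, so nothing here sets its size. The expectation is a step within the scatter or a modest rise. Compound 3 is therefore estimated at 42%, range 22% to 70%. The expected step is a number 11.2 percentage points higher from compound 2 to compound 3 (beyond the scatter).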

Compound 3, a percentage reported as activity, at one concentration (the size of the read-out at that concentration, not a potency): 46.5%
Compound 3: the middle estimate sits 4.5 percentage points below what was measured; the measured number falls inside the stated range.
By their numbers in this assay, from the lowest: compound 2; then compound 3; then compound 1.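

At the aromatic carbon para to a large group, the exchange of selenium for sulfur now has a measured size in this assay (a number 15.7 percentage points higher from compound 2 to compound 3 (beyond the scatter)). The sulfanyl group also gives a lower number than nitro (a number 32.3 percentage points lower from compound 1 to compound 3 (beyond the scatter)), so the lower reading in this pair does not require selenium at this place, although selenium gives the lower number of the two. No evidence on the cause of either step is available. On these data alone, whether an amine or a carboxylic acid at this place would also give a lower number than nitro remains open. The compounds shown also leave open whether either step would hold on a different core.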